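The source may hold more compounds than are shown below. What is called first, only, known or untested is meant among the compounds shown, and "the series" means these compounds.

Of the compounds shown here, three have been measured in a physicochemical assay for solubility; on this read-out lower numbers stand for lower solubility and higher numbers for higher solubility. Compound 1, `O=C(NC1(C(=O)NO)CCCCC1)c1ccc(C#Cc2ccccc2)cc1`, gives < 1000 nM, which is a limit of the assay rather than a number. Compound 2, `O=C(NC1(C(=O)NO)CCN(Cc2ccccc2)CC1)c1ccc(C#Cc2ccccc2)cc1`, likewise gives < 1000 nM, again a limit and not a number. Among the compounds with values here, compound 3, `COCCNC(=O)C[C@H](NC(=O)c1ccc(C#Cc2ccccc2)cc1)C(=O)NO`, is the one compound with a number: in this assay compound 3 gives 78000 nM. So compound 3 stands alone as the only measured value, while the other two results sit at the limit of < 1000 nM in this assay, at which 2 of the 3 values shown sit.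

Compound 4, `O=C(C[C@H](NC(=O)c1ccc(C#Cc2ccccc2)cc1)C(=O)NO)NCCCO`, has not yet been measured. It differs from compound 3 in one place: hydroxymethyl in place of methoxy on a saturated chain carbon, two bonds along the chain from an amide-type nitrogen. The two compounds contain the same atoms, joined differently.

Within the data shown here, no pair of measured compounds differs in only one place, so no measured step shows how a change of this kind moves this assay. Rearranging a methoxy into a hydroxymethyl on a short chain is a small change, and the expected step is small too: for compound 4 the expected movement from compound 3 is a 1.3-fold higher number from compound 3 to compound 4 (0.11 log units; within the scatter), either within the usual scatter or a modest rise. On that basis compound 4 is estimated to give 100000 nM in this assay, with a range from 40000 nM to 250000 nM.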

Compound 4, solubility: 82000 nM
Estimate against measurement, compound 4: 1.2-fold (0.09 log units) above; measured number inside the range.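

Within the data shown here, this pair gives the first readable step in this assay between two compounds that differ in one place: a 1.1-fold higher number from compound 3 to compound 4 (0.02 log units; within the scatter). On a saturated chain carbon, two bonds along the chain from an amide-type nitrogen, hydroxymethyl in place of methoxy therefore leaves the read-out without a change that can be told from scatter, even though hydroxymethyl brings a hydrogen-bond donor that methoxy lacks. Compound 1 and compound 2 add nothing to this reading, as each result is a limit of the assay and not a number: the limit of < 1000 nM in this assay, at which 2 of the 4 values shown sit.

The compounds shown leave open whether this flat result extends beyond methoxy and hydroxymethyl to other groups at the end of the same chain, such as an amine, a carboxylic acid or a longer chain ending in hydroxyl. Among these compounds, they also leave open whether the same change would give a similarly small step on a different core, since this single pair is the only evidence for it.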